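Taking the Acetyl Off Compound 1

A few compounds are considered here, and "the series" means these few. Any claim that something is new, unique, unknown or untested is made for them only; others in the source may bear on it.

Within the data shown here, in an ADME assay on MT4 cells (Homo sapiens) for cytotoxicity, read by MTT assay, with a stated time of 4 days (a higher number here means that more compound is tolerated, a lower number that less compound is tolerated), compound 1 (`COc1ccccc1-c1oc2ccc(NC(C)=O)cc2c(=O)c1O`) gives 385000 nM, the highest of the two numbers measured so far, while compound 2 (`CC(=O)Nc1ccc2oc(-c3cccc(F)c3)c(O)c(=O)c2c1`) gives 26500 nM. Compound 3 (`COc1ccccc1-c1oc2ccc(N)cc2c(=O)c1O`) has not yet been measured. It differs from compound 1 at one place, with hydrogen in place of acetyl on a nitrogen on an aromatic ring. Among the measured compounds shown here, the only measured step is large, a 15-fold lower number from compound 1 to compound 2 (1.16 log units; beyond the scatter), but it leaves the acetamido group untouched and so bears on this change only indirectly. It shows that one change to this series can move the number well beyond the scatter in this assay. For the measured compounds named here, no measured pair shows acetamido to amino. With compound 1 at 385000 nM, the higher end of what has been seen, a moderate step to a lower number is expected, smaller than the measured one, though no step beyond the scatter remains possible. The expected step is a 3.2-fold lower number from compound 1 to compound 3 (0.51 log units; beyond the scatter). For compound 3 the estimated value is 120000 nM, with an expected range from 30000 nM to 400000 nM.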

Compound 3, half-maximal cytotoxic concentration: 222000 nM
Compound 3: middle estimate off by 1.9-fold (0.27 log units), on the low side; measured number inside the range.
By their numbers in this assay, from the lowest: compound 2; then compounds 3 and 1 (each within the scatter of the next).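

In this assay, among these compounds, the exchange of acetamido to amino gives the first direct reading at this nitrogen on the aromatic ring: the step is a 1.7-fold lower number from compound 1 to compound 3 (0.24 log units; within the scatter), so compound 1 and compound 3 cannot be told apart here. Among the compounds shown here, the earlier compounds could not show this, as their only step, a 15-fold lower number from compound 1 to compound 2 (1.16 log units; beyond the scatter), left the acetamido group untouched and changed a group on an aromatic carbon instead. On the core of compound 1, then, the one change shown at this nitrogen stays within the scatter, unlike the one change shown at the aromatic carbon, and no evidence is available to explain this result.

The compounds shown leave open what a longer acyl chain, a methyl group or a methanesulfonyl group on this nitrogen would give in this assay, as a single exchange cannot show how other groups behave at this place. They also leave open whether acetamido to amino would read the same way with 3-fluorophenyl on the core, as it does with 2-methoxyphenyl in compound 1 and compound 3.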